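Working notes: a chain swap on the shared core

This account rests on a few compounds, and the source may have more. Where it says the series, first, only, none or still open, it means among the compounds named here.

Measured so far in an assay for inhibition of RAC-alpha serine/threonine-protein kinase (Homo sapiens), read by HTRF, with a stated time of 1 h; on this read-out lower numbers stand for stronger inhibition and higher numbers for weaker inhibition:
Compound 1 `CNC(=O)C[C@@H]1C[C@@H](c2ccc(Cl)c(Cl)c2)[C@H](NC(=O)c2cc(-c3c(Cl)cnn3C)c(Cl)o2)CN1` gives 2.64 nM.
Compound 2 `Cn1ncc(Cl)c1-c1cc(C(=O)NC2CNCC2c2ccc(C(F)(F)F)cc2)oc1Cl` gives 538 nM.
Compound 3 `Cn1ncc(Cl)c1-c1cc(C(=O)N[C@@H]2CN[C@H](CCO)C[C@H]2c2ccc(F)c(F)c2)oc1Cl` gives 0.98 nM.

Among these three, compound 1 stands second highest. Compound 3 gives the lower number, and that gap lies beyond the usual scatter. Compound 2 gives by far the highest number, also well beyond the scatter. Going by the values given here, compound 2 and compound 3 each differ from compound 1 in more than one place, so no single-change step between measured compounds can be read from what is in hand.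

Compound 4 `Cn1ncc(Cl)c1-c1cc(C(=O)N[C@@H]2CN[C@H](CCN3CCCC3)C[C@H]2c2ccc(Cl)c(Cl)c2)oc1Cl` remains to be measured in this assay. It differs from compound 1 in one place: (pyrrolidin-1-yl)methyl in place of methylcarbamoyl on a saturated chain carbon bound to a saturated ring carbon. Among the compounds with values here, no measured pair isolates a change of this kind, so the expectation rests only on compound 1 and compound 3 both giving low numbers with different groups on the shared core, while compound 2 shows how far the series can move. The step from compound 1 to compound 4 is expected to be small, a 1.3-fold lower number from compound 1 to compound 4 (0.12 log units; within the scatter), within or near the scatter and if anything downward. Compound 4 is accordingly estimated at 2 nM, with a range from 0.5 nM to 8 nM.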

Compound 4, half-maximal inhibitory concentration: 6.41 nM
For compound 4 the middle estimate is 3.2-fold (0.51 log units) below the measured one; low and high end bracket the measured number.
By their numbers in this assay, from the lowest: compound 3; then compound 1; then compound 4; then compound 2.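

In this assay, going by these compounds alone, putting (pyrrolidin-1-yl)methyl in place of methylcarbamoyl on a saturated chain carbon bound to a saturated ring carbon gives a 2.4-fold higher number from compound 1 to compound 4 (0.39 log units; beyond the scatter), the first step that can be read at a single place. This place therefore tolerates the exchange of a chain carrying a carbonyl and a hydrogen-bond donor for one carrying a five-membered non-aromatic ring and no donor, with only a modest rise in the number. Nothing in hand accounts for the direction or size of this step.

The swap changes the ring, the carbonyl and the donor count together, so the compounds shown do not tell which of these carries the step; a pyrrolidine amide on the same chain would keep the carbonyl and the ring without the donor, and an open-chain dimethylamino group would keep the amine without the ring. Going by these compounds, compound 3 differs from compound 1 and compound 4 in more than one place, so its steps to them cannot be read, and a 2-hydroxyethyl chain on the core of compound 1 remains open as well.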